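The source may report more compounds than this note shows. Statements on the series, on what has been measured and on what is new or still open speak of the compounds shown alone.

Of the compounds shown here, three sharing one core have been measured. Compound 1 `CC(Sc1nc2c(cnn2C)c(=O)n1-c1ccccc1)c1ccccn1` gives 242 nM in an assay on isolated protein for inhibition of aldehyde dehydrogenase 1A1 (Homo sapiens); a higher number here means a weaker inhibitor, a lower number a stronger inhibitor. Compound 2 `COc1cccc(C(C)Sc2nc3c(cnn3C)c(=O)n2-c2ccccc2)c1` gives 451 nM in this assay, and compound 3 `CC(Sc1nc2c(cnn2C)c(=O)n1-c1ccccc1)c1ccccc1` gives 130 nM. Compound 3 therefore has the lowest number of the three: the step of a 1.9-fold lower number from compound 1 to compound 3 (0.27 log units; within the scatter) lies within the scatter, while the step of a 3.5-fold lower number from compound 2 to compound 3 (0.54 log units; beyond the scatter) is a modest change beyond the scatter.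

The next compound, compound 4 `COc1ccccc1C(C)Sc1nc2c(cnn2C)c(=O)n1-c1ccccc1`, differs from compound 3 in one place: methoxy in place of hydrogen on an aromatic carbon. The group that enters sits on an aromatic carbon of a six-membered aromatic ring of carbon only, ortho to a large group.

Among the measured compounds shown here, the step that bears most on this change is the one between compound 2 and compound 3, where removing a methoxy from an aromatic carbon lowered the number by a 3.5-fold lower number from compound 2 to compound 3 (0.54 log units; beyond the scatter). The change from compound 3 to compound 4 puts a methoxy back, though on a different aromatic carbon of that ring, so a modest rise in the number, in the direction of weaker inhibition, is expected rather than a fall. The expected step is a 2.1-fold higher number from compound 3 to compound 4 (0.32 log units; beyond the scatter). Compound 4 is therefore estimated at 270 nM, with a range from 110 nM to 650 nM.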

Compound 4, half-maximal inhibitory concentration: 445 nM
Compound 4: the middle estimate sits 1.6-fold (0.22 log units) below what was measured; the measured number falls inside the stated range.
By their numbers in this assay, from the lowest: compounds 3, 1, 4 and 2 (each within the scatter of the next, the first and the last beyond it).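

Methoxy on the aromatic carbon ortho to a large group is not neutral: going from phenyl to 2-methoxyphenyl gives a 3.4-fold higher number from compound 3 to compound 4 (0.53 log units; beyond the scatter) in this assay, so a methoxy on this second ring carbon also weakens inhibition. The ring carbon carrying the methoxy makes no readable difference here, with a 1.0-fold lower number from compound 2 to compound 4 (0.01 log units; within the scatter), so the two methoxy placements shown cannot be told apart. The 2-methoxyphenyl group also stays within the scatter of pyridin-2-yl, with a 1.8-fold higher number from compound 1 to compound 4 (0.26 log units; within the scatter), so the plain phenyl of compound 3 stands clearly apart from the two methoxy compounds but not from compound 1.

Nothing available explains why the methoxy raises the number at either ring carbon. From the compounds shown here alone, it also remains open whether this rise belongs to methoxy itself or would come with any group on that aromatic carbon, a question that a methyl, a fluorine or a hydroxyl at the same place could help to answer.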